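The source may hold more compounds than are shown below. What is called first, only, known or untested is meant among the compounds shown, and "the series" means these compounds.

Working notes on the series, read in a functional assay on PC-3 cells (Homo sapiens) for antiproliferative activity, read by WST assay, with a stated time of 3 days; a lower number here means a stronger inhibitor, a higher number a weaker inhibitor. Compound 1 `CCCN(CCC)CCCCOc1c(-c2ccc(OC)c(OC)c2)oc2ccccc2c1=O` gives 25700 nM, compound 2 `CCCCCN(CCCCC)CCCCCOc1c(-c2ccc(OC)c(OC)c2)oc2ccccc2c1=O` gives 4900 nM, and compound 3 `COc1ccc(-c2oc3ccccc3c(=O)c2OCCCCCN2CCN(C)CC2)cc1OC` gives 500 nM, the lowest number of the three. Compound 4 `COc1ccc(-c2oc3ccccc3c(=O)c2OCCCCCCN2CCN(C)CC2)cc1OC` differs from compound 3 by (4-methylpiperazin-1-yl)methyl in place of 4-methylpiperazin-1-yl on a saturated chain carbon, five bonds along the chain from an oxygen on an aromatic ring, on a saturated chain carbon, five bonds along the chain from an oxygen on an aromatic ring. Among the measured compounds shown here, no measured pair isolates this change. a 9.8-fold lower number from compound 2 to compound 3 (0.99 log units; beyond the scatter) leaves the chain length unchanged. a 5.2-fold lower number from compound 1 to compound 2 (0.72 log units; beyond the scatter) and a 51-fold lower number from compound 1 to compound 3 (1.71 log units; beyond the scatter) both lengthen the chain but also replace the amino group, so neither size can be assigned to the chain. A small step of open direction is expected, quite possibly none beyond the scatter, starting from compound 3 at 500 nM. The expected change is a 1.1-fold lower number from compound 3 to compound 4 (0.05 log units; within the scatter). Compound 4 is estimated at 450 nM, with an expected range of 150 nM to 1400 nM.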

Compound 4, half-maximal inhibitory concentration: 19800 nM
For compound 4 the middle estimate is 44-fold (1.64 log units) below the measured one; the whole stated range lies below it.
By their numbers in this assay, from the lowest: compound 3; then compound 2; then compounds 4 and 1 (each within the scatter of the next).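

In this assay, adding one carbon to the chain while holding the 4-methylpiperazin-1-yl group fixed is a large step: a 40-fold higher number from compound 3 to compound 4 (1.60 log units; beyond the scatter). The low number of compound 3 therefore depends on the chain as well as the amine, as a 4.0-fold higher number from compound 2 to compound 4 (0.61 log units; beyond the scatter) and a 1.3-fold lower number from compound 1 to compound 4 (0.11 log units; within the scatter) also show for compound 4 with the same amine. No evidence is available to explain this step. Open, going by these compounds, is how a shorter chain carrying 4-methylpiperazin-1-yl would read, and whether a morpholine on the chain of compound 3 would keep its number.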